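The source may report more compounds than this note shows. Statements on the series, on what has been measured and on what is new or still open speak of the compounds shown alone.

Compound 1 `Cc1n[nH]c(C(=O)O)c1Cc1cccc(-c2ccc(C#N)cc2)c1` gives 13% in an assay on isolated protein for inhibition of 2-Hydroxyacid oxidase 2 (Homo sapiens), tested at 1 uM; on this read-out higher numbers stand for a stronger effect at the one concentration tested and lower numbers for a weaker effect. Among the three compounds measured so far it holds the second highest number, with compound 3 `Cc1n[nH]c(C(=O)O)c1Cc1ccccc1Oc1ccccc1` at 9% and compound 2 `Cc1n[nH]c(C(=O)O)c1Cc1cccc(-c2ccc(C(N)=O)cc2)c1` at 18%, both gaps lying within the scatter. Compound 4 `Cc1n[nH]c(C(=O)O)c1Cc1cccc(C#N)c1` differs from compound 1 in one place: cyano in place of 4-cyanophenyl on an aromatic carbon. Among the measured compounds shown here, the only single-point step measured, a number 5 percentage points higher from compound 1 to compound 2 (within the scatter), concerns carbamoyl in place of cyano and does not touch the loss of a ring; compound 3 carries a different arrangement altogether. For the measured compounds named here, no measured step therefore bears on this change, and no shift beyond the scatter is expected in this assay. Compound 4 is estimated at 9% (range -4% to 22%), which means an expected step of a number 4 percentage points lower from compound 1 to compound 4 (within the scatter).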

Compound 4, a percentage reported as inhibition, at one concentration (the size of the read-out at that concentration, not a potency): 6%
Estimate against measurement, compound 4: 3 percentage points above, within the range that was stated.
By their numbers in this assay, from the lowest: compounds 4, 3, 1 and 2 (each within the scatter of the next, the first and the last beyond it).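

Replacing the 4-cyanophenyl with cyano on this aromatic carbon, a change that removes the outer ring but keeps a nitrile, gives a number 7 percentage points lower from compound 1 to compound 4 (within the scatter) in this assay. At this position, then, the outer ring is not shown to matter for this read-out, since the step does not exceed the scatter. No measurement at hand explains this result.

As far as these compounds go, it remains open whether an amine or a longer chain on this aromatic carbon would give a step beyond the scatter. The compounds shown also leave open whether any change at this position can separate clearly from compound 1 in this assay.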